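Swapping the Phenyl of an Anilide for a Thiazole

A few compounds are considered here, and "the series" means these few. Any claim that something is new, unique, unknown or untested is made for them only; others in the source may bear on it.

Of the compounds shown here, two sharing a single core have been tested so far in a functional assay on HepG2 cells (Homo sapiens) for inhibition, read by MTT assay, with a stated time of 72 h; on this read-out higher numbers stand for weaker inhibition and lower numbers for stronger inhibition. Compound 1 `O=C(Nc1ccccc1)C1CCN(C/C=C/c2ccccc2)CC1` gives 90900 nM in this assay, the highest of the two numbers and therefore the weaker inhibitor shown. Compound 2 `CCCc1ccc(NC(=O)C2CCN(C/C=C/c3ccccc3)CC2)cc1` gives 9410 nM in this assay. Among the compounds with values here, the one known step, a 9.7-fold lower number from compound 1 to compound 2 (0.98 log units; beyond the scatter), comes from propyl in place of hydrogen on an aromatic carbon.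

Compound 3 `O=C(Nc1nccs1)C1CCN(C/C=C/c2ccccc2)CC1` differs from compound 1 in another way: 1,3-thiazol-2-yl in place of phenyl on an amide-type nitrogen. Within the data shown here, nothing measured bears on this change, since the only known step alters an aromatic carbon, not the amide-type nitrogen. Without a comparable precedent, no step beyond the scatter can be expected in this assay. Compound 3 is therefore expected to give about 70000 nM in this assay, within a range of 25000 nM to 200000 nM, which would mean a step of a 1.3-fold lower number from compound 1 to compound 3 (0.11 log units; within the scatter).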

Compound 3, half-maximal inhibitory concentration: 22400 nM
Estimate against measurement, compound 3: 3.1-fold (0.49 log units) above; the whole stated range lies above it.
By their numbers in this assay, from the lowest: compound 2; then compound 3; then compound 1.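

In this assay, the ring on the amide-type nitrogen turns out to matter: 1,3-thiazol-2-yl in place of phenyl gives a 4.1-fold lower number from compound 1 to compound 3 (0.61 log units; beyond the scatter) and so moves the number beyond the scatter. Until now, only a change on an aromatic carbon had been seen to do this. The thiazole still falls short of the 4-propylphenyl group, with a 2.4-fold higher number from compound 2 to compound 3 (0.38 log units; beyond the scatter) as the step between these two groups on the same nitrogen, and nothing measured here explains either step.

The compounds shown leave open whether a propyl group on the thiazole ring would lower the number further, as it does on the phenyl ring. They also leave open how other rings on this nitrogen, such as pyridine, would compare, and whether a longer chain such as pentyl would do more than propyl.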